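From Chloro to Ethynyl: Compound 4 in Prospect

A few compounds are considered here, and "the series" means these few. Any claim that something is new, unique, unknown or untested is made for them only; others in the source may bear on it.

Measured so far in a functional assay on CHO cells for agonist activity at metabotropic glutamate receptor 5 (Homo sapiens), read by inositol phosphate accumulation; a lower number here means a stronger inhibitor, a higher number a weaker inhibitor:
- Compound 1, `COc1ncccc1C#Cc1csc(C)n1`, gives 228 nM.
- Compound 2, `Cc1nc(C#Cc2cccnc2OS(C)(=O)=O)cs1`, gives > 10000 nM, which is a limit of the assay rather than a number.
- Compound 3, `Cc1nc(C#Cc2cccnc2Cl)cs1`, gives 45.5 nM.

Compound 3 holds the lowest of the two actual numbers; the step of a 5.0-fold lower number from compound 1 to compound 3 (0.70 log units; beyond the scatter) separates it from the other. Compound 4, `C#Cc1ncccc1C#Cc1csc(C)n1`, differs by ethynyl in place of chloro on an aromatic carbon. Among the compounds with values here, no measured step exchanges chloro for ethynyl. The nearest guidance is a 5.0-fold lower number from compound 1 to compound 3 (0.70 log units; beyond the scatter), a modest move between two groups at this carbon, while an at least 43-fold higher number from compound 1 to compound 2 (1.64 log units; beyond the scatter) and an at least 210-fold lower number from compound 2 to compound 3 (2.34 log units; beyond the scatter) show that the (methylsulfonyl)oxy group pushes the value to the limit (the limit of > 10000 nM in this assay, at which 1 of the 3 values shown sits). Ethynyl brings two heavy atoms, closer to chloro than to that group, so compound 4 is expected to stay near compound 3, a step of a 1.5-fold higher number from compound 3 to compound 4 (0.19 log units; within the scatter). The estimate for compound 4 is 70 nM, ranging from 20 nM to 300 nM.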

Compound 4, half-maximal inhibitory concentration: 192 nM
Compound 4: middle estimate off by 2.7-fold (0.44 log units), on the low side; measured number inside the range.
By their numbers in this assay, from the lowest: compound 3; then compounds 4 and 1 (each within the scatter of the next). At a limit, above all of these: compound 2.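

Exchanging chloro for ethynyl at this carbon next to the ring nitrogen is not a neutral swap: the change gives a 4.2-fold higher number from compound 3 to compound 4 (0.63 log units; beyond the scatter). Ethynyl and methoxy are not separated here, with a 1.2-fold lower number from compound 1 to compound 4 (0.07 log units; within the scatter), so among the numbers measured so far chloro alone gives the lowest. The (methylsulfonyl)oxy group remains apart, with an at least 52-fold lower number from compound 2 to compound 4 (1.71 log units; beyond the scatter), but that step starts from a value that is only a limit of the assay: the limit of > 10000 nM in this assay, at which 1 of the 4 values shown sits.

Why chloro gives the lower number stays open. So does how a bromo group, a methyl group or an amine at this carbon would compare with chloro.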